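A few compounds are considered here, and "the series" means these few. Any claim that something is new, unique, unknown or untested is made for them only; others in the source may bear on it.

Working notes on the series. In a physicochemical assay for solubility, measured as kinetic solubility, with a stated time of 1 h, at pH 7.4 (a lower number here means a less soluble compound, a higher number a more soluble compound), compound 1 `CC(=O)Nc1nc(-c2ccc(Cl)c(Cl)c2)cs1` gives only a limit of the assay, namely < 1000 nM and no number. Compound 2 `CC(=O)Nc1nc(-c2ccc(Cl)cc2)cs1` gives 1000 nM in this assay. Among the measured compounds shown here, the single measured step, a number no lower from compound 1 to compound 2 (the limit leaves the size open), rests on the limit of < 1000 nM in this assay, at which 1 of the 3 values shown sits, and its size stays open. Compound 3 `N#CCC(=O)NC1=NN(c2ccc(Cl)c(Cl)c2)CC1` gives 202000 nM in this assay and stands highest of the two numbers shown; the nearest number, that of compound 2, lies far beneath it, beyond the scatter. For the measured compounds named here, no step is given between compound 2 and compound 3; their cores differ. Compound 4 `O=C(NC1=NN(c2ccc(Cl)c(Cl)c2)CC1)c1cncnc1` is not yet measured in this assay. It differs from compound 3 in one place: pyrimidin-5-yl in place of cyanomethyl on a carbonyl carbon. Going by the values given here, no measured step bears on this change; the only measured step concerns hydrogen in place of chloro on an aromatic carbon and is itself a limit. In this assay the expected step is a 2.5-fold lower number from compound 3 to compound 4 (0.40 log units; beyond the scatter), modest and downward, with wide uncertainty. Compound 4 is expected to give 80000 nM in this assay, within a range from 20000 nM to 250000 nM.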

Compound 4, solubility: 8000 nM
Beside the measured number, compound 4's estimate is 10-fold (1.00 log units) above it; the whole stated range lies above it.
By their numbers in this assay, from the lowest: compound 2; then compound 4; then compound 3.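

On the carbonyl carbon whose other neighbour is the amide-type nitrogen, pyrimidin-5-yl in place of cyanomethyl gives a clear change in this assay: a 25-fold lower number from compound 3 to compound 4 (1.40 log units; beyond the scatter). Among the compounds shown here, the only earlier step concerned hydrogen in place of chloro on an aromatic carbon and could not be sized, so this is the first sized step and the first to show that this position can move the number with the rest of compound 3 unchanged. Nothing measured here accounts for the size of this step.

As far as these compounds go, whether the step follows the entering aromatic ring, its two ring nitrogens or the loss of the nitrile stays open, since this single change alters all of them together. Phenyl or a longer chain ending in a nitrile on the same carbonyl carbon would bear on that question.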